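Cyclic amide replaces the acid on the shared core

The source may hold more compounds than are shown below. What is called first, only, known or untested is meant among the compounds shown, and "the series" means these compounds.

Of the compounds shown here, three that share a core have been measured in an assay for positive allosteric modulation of metabotropic glutamate receptor 3 (Rattus norvegicus); on this read-out higher numbers stand for an effect only at larger amounts of compound and lower numbers for an effect already at smaller amounts. Compound 1, `CNC(=O)c1cc(OCCCCOc2ccc(C(=O)CC(C)(C)C)c(O)c2C)ccc1F`, gives 476 nM. Compound 2, `COc1cc(OCCCCOc2ccc(C(=O)CC(C)(C)C)c(O)c2C)cc(C(=O)O)c1`, gives 703 nM. Compound 3, `Cc1cc(C(=O)O)ccc1OC[C@H](C)COc1ccc(C(=O)CC(C)(C)C)c(O)c1C`, gives 1520 nM, the highest of the three numbers, and its gaps to compound 2 and to compound 1 both lie beyond the usual scatter.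

Compound 4, `Cc1c(OC[C@@H](C)COc2ccc3c(c2)C(=O)NC3)ccc(C(=O)CC(C)(C)C)c1O`, has not yet been measured. It differs from compound 3 in one place: a group of 10 heavy atoms (8 carbon, 1 nitrogen, 1 oxygen; one five-membered non-aromatic ring with 1 hetero atom, one six-membered aromatic ring of carbon only) in place of a group of 10 heavy atoms (8 carbon, 2 oxygen; one six-membered aromatic ring of carbon only), on an oxygen on a saturated carbon. The acid of compound 3 thus gives way to a five-membered ring holding a nitrogen, while the count of donors and acceptors stays the same.

Among the measured compounds shown here, no measured pair shows this exact change, so the size of the step is uncertain. Compound 1, which carries an amide rather than an acid and gives 476 nM, hints that such a group is at least tolerated on this scaffold. A modest move toward a lower number is therefore expected, with a 1.7-fold lower number from compound 3 to compound 4 (0.23 log units; within the scatter) as the guess. Compound 4 is estimated at 900 nM, within a range from 300 nM to 2700 nM.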

Compound 4, half-maximal effective concentration: "not active" (no number reported)
Nothing numeric was reported for compound 4, so the estimate cannot be set against anything.
By their numbers in this assay, from the lowest: compounds 1 and 2 (each within the scatter of the next); then compound 3.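

Among the compounds shown here, compound 4 is reported as not active in this assay, without a number, so no step from compound 3 to compound 4 can be read. Nothing shown offers an explanation for this result. The compounds shown leave open how the same replacement would fare on other compounds sharing the core.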